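The compounds below may be only part of what the source reports. "The series", "measured", "known", "first", "only" and "open" are said of these compounds alone.

Compound 1 `COc1cc(OC)c(C(=O)/C=C/c2ccccc2OC)c(OC)c1`: 8100 nM
Compound 2 `COc1cc(OC)c(C(=O)/C=C/c2ccccc2SC)c(OC)c1`: 7600 nM
Compound 3 `COc1cc(OC)c(C(=O)/C=C/c2ccc(Cl)cc2)c(OC)c1`: 5800 nM

These values come from a functional assay on PC-3 cells (Homo sapiens) for cytotoxicity, with a stated time of 48 h; a higher number here means a weaker inhibitor, a lower number a stronger inhibitor. Compound 1 stands level with the other two: the data show a 1.1-fold lower number from compound 1 to compound 2 (0.03 log units; within the scatter) and a 1.4-fold lower number from compound 1 to compound 3 (0.15 log units; within the scatter), and neither step exceeds the scatter. Compound 4 `COc1cc(OC)c(C(=O)/C=C/c2ccc(F)cc2)c(OC)c1` has not yet been measured. It carries 4-fluorophenyl in place of 2-methoxyphenyl on a double-bonded chain carbon bound to a double-bonded chain carbon. The closest guide is compound 3, which has 4-chlorophenyl at that same place and shows a 1.4-fold lower number from compound 1 to compound 3 (0.15 log units; within the scatter). The companion change shows a 1.3-fold lower number from compound 2 to compound 3 (0.12 log units; within the scatter). No step beyond the scatter is therefore expected in this assay. The estimate means a 1.2-fold lower number from compound 1 to compound 4 (0.10 log units; within the scatter). For compound 4 the expected value is 6500 nM, with an estimated range of 3500 nM to 12000 nM.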

Compound 4, half-maximal inhibitory concentration: 5500 nM
Compound 4: the middle estimate sits 1.2-fold (0.07 log units) above what was measured; the measured number falls inside the stated range.
By their numbers in this assay, from the lowest: compounds 4, 3, 2 and 1 (each within the scatter of the next).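

In this assay, placing 4-fluorophenyl on the double-bonded chain carbon gives a 1.5-fold lower number from compound 1 to compound 4 (0.17 log units; within the scatter) and a 1.4-fold lower number from compound 2 to compound 4 (0.14 log units; within the scatter) and so adds no step beyond the scatter at this position. The narrower change of fluoro in place of chloro on an aromatic carbon gives a 1.1-fold lower number from compound 3 to compound 4 (0.02 log units; within the scatter) and so leaves these two groups indistinguishable in this assay. No measurement at hand bears on these results.

Going by these compounds, whether an amine or a carboxylic acid on this ring would produce a step beyond the scatter remains open.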